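Cytotoxicity notes on the arylidene succinimide anilides

A few compounds are considered here, and "the series" means these few. Any claim that something is new, unique, unknown or untested is made for them only; others in the source may bear on it.

Three members of the series have been run in an ADME assay on HCT-116 cells (Homo sapiens) for cytotoxicity, read by MTT assay, with a stated time of 72 h (on this read-out higher numbers stand for weaker inhibition and lower numbers for stronger inhibition), and none has returned a number. Compound 1 `CCc1ccc(NC(=O)c2cccc(/C=C3\CC(=O)N(c4ccccc4)C3=O)c2)cc1` gives > 100000 nM, which is a limit of this assay rather than a measured value. Compound 2 `COc1cc(NC(=O)c2cccc(/C=C3\CC(=O)N(c4ccccc4)C3=O)c2)cc(OC)c1OC` likewise gives > 100000 nM in this assay, again a limit. Compound 3 `CCCCCN1C(=O)C/C(=C\c2cccc(C(=O)Nc3ccc(OC)cc3)c2)C1=O` gives > 100000 nM in this assay, also a limit. Compound 1 thus stands at the same limit as every other value shown; the summary the limit of > 100000 nM in this assay, at which 3 of the 3 values shown sit, covers all three.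

Compound 4 `CSc1cccc(NC(=O)c2cccc(/C=C3\CC(=O)N(c4ccccc4)C3=O)c2)c1` is the next member to be run in this assay. It differs from compound 1 by 3-(methylsulfanyl)phenyl in place of 4-ethylphenyl on an amide-type nitrogen: 4-ethylphenyl leaves and 3-(methylsulfanyl)phenyl enters, on an amide-type nitrogen whose other neighbour is a carbonyl carbon. Within the data shown here, no step between measured compounds is available, and the three values shown give no spread to work from.

The step of a number no higher from compound 1 to compound 4 (the limit leaves the size open) is expected to be none beyond the scatter, since every measured value sits at the limit (the limit of > 100000 nM in this assay, at which 3 of the 3 values shown sit). Compound 4 is estimated at 100000 nM in this assay, in the range 40000 nM to 300000 nM, and most likely it will again be reported only as a limit.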

Compound 4, half-maximal inhibitory concentration: 65200 nM
Compound 4: the middle estimate sits 1.5-fold (0.19 log units) above what was measured; the measured number falls inside the stated range.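

Among these compounds, compound 4 is the first member of the series to return a number rather than a limit: in this assay, compound 4 gives 65200 nM. Placing 3-(methylsulfanyl)phenyl instead of 4-ethylphenyl on the amide-type nitrogen gives an at least 1.5-fold lower number from compound 1 to compound 4 (0.18 log units; that floor lies within the scatter), so this position tolerates the exchange, but the change cannot be called real on the printed floor, and its full size stays open. The series as a whole still rests mainly at the assay limit: the limit of > 100000 nM in this assay, at which 3 of the 4 values shown sit.

Open, on these data alone, is whether the number in this assay would move with a longer chain on the sulfur, such as butylsulfanyl, or with a carboxylic acid or an amine in place of the methylsulfanyl group. Also open, as far as these compounds go, is whether any such group would give a step beyond the scatter.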